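The source may hold more compounds than are shown below. What is called first, only, known or untested is meant among the compounds shown, and "the series" means these compounds.

Compound 3 `O=C(CN1CCN(c2nnc(Cc3ccccc3)c3ccccc23)CC1)Nc1cccc(Br)c1` carries the highest of the two numbers obtained in a functional assay on HT-29 cells (Homo sapiens) for cytotoxicity, read by MTT assay, with a stated time of 72 h; on this read-out lower numbers stand for stronger inhibition and higher numbers for weaker inhibition; its value, 13400 nM, sits close to that of compound 1 `O=C(CN1CCN(c2nnc(Cc3ccccc3)c3ccccc23)CC1)Nc1ccc(F)c(F)c1`, which gives 9510 nM, and compound 2 `Cc1ccc(NC(=O)CN2CCN(c3nnc(Cc4ccccc4)c4ccccc34)CC2)c(C)c1` was reported as "not active" (no number reported) in this assay. Compound 4 `O=C(CN1CCN(c2nnc(Cc3ccccc3)c3ccccc23)CC1)Nc1cccc(F)c1` differs from compound 3 by fluoro in place of bromo on an aromatic carbon. For the measured compounds named here, the only measured step touching the aryl group on the amide nitrogen is a 1.4-fold higher number from compound 1 to compound 3 (0.15 log units; within the scatter), and it stays within the scatter. Going by the values given here, no measured pair isolates fluoro against bromo, so nothing beyond the scatter is expected here, and the step of a 1.2-fold lower number from compound 3 to compound 4 (0.09 log units; within the scatter) is the estimate. Compound 4 is therefore expected to give 11000 nM in this assay, within a range of 5000 nM to 30000 nM.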

Compound 4, half-maximal inhibitory concentration: 95000 nM
Estimate against measurement, compound 4: 8.6-fold (0.94 log units) below; measured number above the stated range.
By their numbers in this assay, from the lowest: compounds 1 and 3 (each within the scatter of the next); then compound 4.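

In this assay the aryl group on the amide nitrogen proves sensitive to a single substituent, which the earlier step within the scatter did not show. There is a 7.1-fold higher number from compound 3 to compound 4 (0.85 log units; beyond the scatter) with fluoro in place of bromo and a 10-fold higher number from compound 1 to compound 4 (1.00 log units; beyond the scatter) with hydrogen in place of fluoro, both beyond the scatter. Compound 4 thus stands apart from compound 1 and compound 3, although those two remain within the scatter of each other.

Going by these compounds, whether chloro, methoxy or an amine on this aromatic carbon would track with bromo or with fluoro remains open. Nothing shown explains why these steps are so large.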